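The source may report more compounds than this note shows. Statements on the series, on what has been measured and on what is new or still open speak of the compounds shown alone.

Series notes. Compound 1 `COc1cc2c(Oc3ccc(NC(=O)c4nn(-c5ccccc5C(F)(F)F)c(=O)cc4C)cc3F)ccnc2cc1OCCCN1CCCCC1` and compound 2 `COc1cc2c(Oc3ccc(NC(=O)c4nn(-c5ccccc5C(F)(F)F)c(=O)cc4C)cc3F)ccnc2cc1OCCCN1CCC(C)CC1` share one core; compound 3 `COc1cc2c(Oc3ccc(NC(=O)c4nn(-c5ccc(Cl)cc5)c(=O)cc4C)cc3F)ccnc2cc1OCCCN1CCCCC1` and compound 4 `COc1cc2c(Oc3ccc(NC(=O)c4nn(-c5ccc(Cl)cc5)c(=O)cc4C)cc3F)ccnc2cc1OCCCN1CCC(C)CC1` share another. In a functional assay on A549 cells (Homo sapiens) for inhibition, read by MTT assay, with a stated time of 72 h (on this read-out higher numbers stand for weaker inhibition and lower numbers for stronger inhibition), compound 1 gives 140 nM. In this assay compound 2 gives 160 nM. In this assay compound 3 gives 320 nM.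

The change from compound 1 to compound 2 is methyl in place of hydrogen on a saturated ring carbon. Its step in this assay is a 1.1-fold higher number from compound 1 to compound 2 (0.06 log units; within the scatter), so the two numbers cannot be told apart.

The two cores differ as 4-chlorophenyl in place of 2-(trifluoromethyl)phenyl on an aromatic nitrogen. The step in this assay is a 2.3-fold higher number from compound 1 to compound 3 (0.36 log units; beyond the scatter). Compound 3 carries the highest of the three numbers, but its gap to compound 2 lies within the scatter, so nothing separates those two.

Compound 4 is not yet measured in this assay. It differs from compound 3 as methyl in place of hydrogen on a saturated ring carbon. The place reads word for word as it does for the change from compound 1 to compound 2, so this is the same change, made for the second time in the set. That change has so far been made only once. Among the measured compounds shown here, nothing shows whether its size depends on the core it sits on, and the only guide is the single earlier step. The expected step is a 1.1-fold higher number from compound 3 to compound 4 (0.04 log units; within the scatter), resting on the earlier 1.1-fold higher number from compound 1 to compound 2 (0.06 log units; within the scatter) in this assay. Compound 4 is accordingly expected to give about 350 nM in this assay, with a likely range from 180 nM to 700 nM.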

Compound 4, half-maximal inhibitory concentration: 210 nM
For compound 4 the middle estimate is 1.7-fold (0.22 log units) above the measured one; measured number inside the range.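

In this assay, the second making of the methyl change, 4-methylpiperidin-1-yl in place of piperidin-1-yl, gives a 1.5-fold lower number from compound 3 to compound 4 (0.18 log units; within the scatter), and this step does not differ from the one on the other core: the same change on two cores in this assay, a 1.1-fold higher number (0.06 log units; within the scatter) from compound 1 to compound 2 and a 1.5-fold lower number (0.18 log units; within the scatter) from compound 3 to compound 4, 1.7-fold (0.24 log units) apart, within the scatter of two such steps

The change between the two aryl groups, read on the 4-methylpiperidin-1-yl pair, gives a 1.3-fold higher number from compound 2 to compound 4 (0.12 log units; within the scatter), and although only the earlier step on the piperidin-1-yl pair lies beyond the scatter, the two steps cannot be separated: the same change on two cores in this assay, a 2.3-fold higher number (0.36 log units; beyond the scatter) from compound 1 to compound 3 and a 1.3-fold higher number (0.12 log units; within the scatter) from compound 2 to compound 4, 1.7-fold (0.24 log units) apart, within the scatter of two such steps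

The methyl change therefore carries across these two cores with no detectable dependence on the core, but both of its steps are within the scatter, so this shows only that it is small on each core and does not exclude a core dependence smaller than the scatter, nor does it extend to any further core.

The compounds shown leave open whether a different group on the same ring carbon, such as a hydroxyl, a primary amine or an ethyl, would also give a step within the scatter on both cores. They also leave open how an unsubstituted phenyl on the aromatic nitrogen would compare with 4-chlorophenyl and 2-(trifluoromethyl)phenyl.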